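Changing the aryl end of the urea in a diaryl urea series

This account rests on a few compounds, and the source may have more. Where it says the series, first, only, none or still open, it means among the compounds named here.

Compound 2 `CCN(CC)CCn1cnnc1-c1cc(Oc2ccc(NC(=O)Nc3ccc(Cl)c(C(F)(F)F)c3)cc2F)ccn1` gives 900 nM in a functional assay on HT-29 cells (Homo sapiens) for antiproliferative activity, read by MTT assay, with a stated time of 72 h (on this read-out higher numbers stand for weaker inhibition and lower numbers for stronger inhibition), the highest of the two numbers shown, with compound 1 `CN(C)CCn1cnnc1-c1cc(Oc2ccc(NC(=O)Nc3ccc(Cl)c(C(F)(F)F)c3)cc2F)ccn1` nearest at 880 nM. Within the data shown here, the single measured step, a 1.0-fold higher number from compound 1 to compound 2 (0.01 log units; within the scatter), concerns only the amine at the end of the chain. Compound 3 `CCN(CC)CCn1cnnc1-c1cc(Oc2ccc(NC(=O)Nc3ccc(Cl)cc3Cl)cc2F)ccn1` differs from compound 2 elsewhere: 2,4-dichlorophenyl in place of 4-chloro-3-(trifluoromethyl)phenyl on an amide-type nitrogen. Among the measured compounds shown here, no measured step touches this part of the molecule, so the expectation rests on compound 2 alone, widened for an untested change. For compound 3 the expected step is a 1.7-fold higher number from compound 2 to compound 3 (0.22 log units; within the scatter), a modestly higher number. Compound 3 is therefore estimated at 1500 nM, within 450 nM to 5000 nM.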

Compound 3, half-maximal inhibitory concentration: 3590 nM
Compound 3: the middle estimate sits 2.4-fold (0.38 log units) below what was measured, within the range that was stated.
By their numbers in this assay, from the lowest: compounds 1 and 2 (each within the scatter of the next); then compound 3.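

In this assay, 2,4-dichlorophenyl in place of 4-chloro-3-(trifluoromethyl)phenyl on the amide-type nitrogen gives a 4.0-fold higher number from compound 2 to compound 3 (0.60 log units; beyond the scatter), which means weaker inhibition and shows that this end of the urea affects the read-out beyond the scatter, unlike the earlier change at the amine. The change removes the trifluoromethyl group and brings in a second chlorine together, so this single step cannot separate the two. Nothing available explains the difference. Still open, from the compounds shown here alone, is how a plain phenyl or a 4-methoxyphenyl would compare on that nitrogen, and whether dimethylamino at the chain end would behave the same way alongside 2,4-dichlorophenyl.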